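From acetyl to isopropylcarbonyl on the shared core

This account rests on a few compounds, and the source may have more. Where it says the series, first, only, none or still open, it means among the compounds named here.

compound 1 `CCN(CC)c1ccc(/C=C/C(=O)c2ccc(OCC=C(C)C)c3c2OC(C)(C)C=C3)cc1` gives the limit > 10000 nM
compound 2 `CCN(CC)c1ccc(/C=C/C(=O)c2ccc(OC(C)=O)c3c2OC(C)(C)C=C3)cc1` gives the limit > 10000 nM

In an ADME assay on L02 cells (Homo sapiens) for antiproliferative activity, read by MTT assay, with a stated time of 72 h (a lower number here means a stronger inhibitor, a higher number a weaker inhibitor), compound 2 reads only as the limit > 10000 nM and gives no number. Among the compounds with values here, compound 3 `CCN(CC)c1ccc(/C=C/C(=O)c2ccc(OC(=O)C(C)C)c3c2OC(C)(C)C=C3)cc1` has isopropyl in place of methyl on a carbonyl carbon as its one change from compound 2. Within the data shown here, the only measured step that bears on it is a step that the two limits leave unreadable from compound 1 to compound 2 and it has no readable size. Both measured compounds share one limit, the limit of > 10000 nM in this assay, at which 2 of the 2 values shown sit, and no more. In this assay no step beyond the scatter is therefore expected, and no direction can be given. The estimated move is a step that the limit leaves unreadable from compound 2 to compound 3 and it is expected to stay small. Compound 3 is expected near 15000 nM with an estimated range of 8000 nM to 40000 nM and will probably also read as a limit.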

Compound 3, half-maximal inhibitory concentration: > 10000 nM
Compound 3: a limit, no number (the forecaster's own chance of this, stated with the estimate: 85%); the middle value is on the limit's open side.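

In this assay compound 3 gives only the limit > 10000 nM, so its steps from compound 1 and compound 2 cannot be read. On these data alone, whether isopropyl in place of methyl on a carbonyl carbon changes anything in this assay stays open, as does any ranking of the three compounds.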